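Swapping the pyridylmethyl sulfide of compound 3 for an acetylphenyl group

This account rests on a few compounds, and the source may have more. Where it says the series, first, only, none or still open, it means among the compounds named here.

Three ribosylated aminopurine sulfides have been measured in an assay on isolated protein for binding affinity to Equilibrative nucleoside transporter 1 (Homo sapiens); on this read-out lower numbers stand for stronger inhibition and higher numbers for weaker inhibition. Compound 1 `CCC(C)Sc1nc(N)nc2c1ncn2[C@@H]1O[C@H](CO)[C@@H](O)[C@H]1O` gives 63100 nM, compound 2 `Nc1nc(SCc2ccccc2Cl)c2ncn([C@@H]3O[C@H](CO)[C@@H](O)[C@H]3O)c2n1` gives 13500 nM, and compound 3 `Cc1cccc(CSc2nc(N)nc3c2ncn3[C@@H]2O[C@H](CO)[C@@H](O)[C@H]2O)n1` gives 11500000 nM, the highest number of the three. The measured steps were a 180-fold higher number from compound 1 to compound 3 (2.26 log units; beyond the scatter) and an 850-fold higher number from compound 2 to compound 3 (2.93 log units; beyond the scatter), so the (6-methylpyridin-2-yl)methyl group stands apart from both other sulfur substituents. Compound 4 `CC(=O)c1ccccc1Sc1nc(N)nc2c1ncn2[C@@H]1O[C@H](CO)[C@@H](O)[C@H]1O` differs from compound 3 as follows: 2-acetylphenyl in place of (6-methylpyridin-2-yl)methyl on a sulfur. Because the ring-bearing group of compound 2 gave 13500 nM and the alkyl group of compound 1 gave 63100 nM, a large step downward in this assay is expected for compound 4, estimated as a 190-fold lower number from compound 3 to compound 4 (2.28 log units; beyond the scatter). Compound 4 is therefore expected to give about 60000 nM, within a range from 5000 nM to 700000 nM.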

Compound 4, half-maximal inhibitory concentration: 447000 nM
The estimate for compound 4 lay 7.5-fold (0.87 log units) below the measured number; low and high end bracket the measured number.
By their numbers in this assay, from the lowest: compound 2; then compound 1; then compound 4; then compound 3.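

In this assay, 2-acetylphenyl on this sulfur gives a 26-fold lower number from compound 3 to compound 4 (1.41 log units; beyond the scatter), so the very high number of compound 3 does not extend to every ring-bearing group here. The same group still gives a 33-fold higher number from compound 2 to compound 4 (1.52 log units; beyond the scatter) and a 7.1-fold higher number from compound 1 to compound 4 (0.85 log units; beyond the scatter), which places the sec-butyl compound 1 among the ring-bearing compounds, so carrying a ring does not by itself set the number at this position. No measurement available here accounts for these differences.

From the compounds shown here alone, whether the acetyl group or the directly attached ring drives the change remains open. An unsubstituted phenyl or a 2-chlorophenyl on this sulfur would separate the two.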